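Acetyl for methoxy in a growth hormone secretagogue receptor agonist series

A few compounds are considered here, and "the series" means these few. Any claim that something is new, unique, unknown or untested is made for them only; others in the source may bear on it.

Measured so far:
compound 1, `COc1ccc(NS(=O)(=O)c2ccc(-c3ccccn3)s2)cc1N1C[C@@H](C)N[C@@H](C)C1` — 0.9
compound 2, `COc1ccc(N2C[C@@H](C)N[C@@H](C)C2)cc1NS(=O)(=O)c1ccc(-c2ccccn2)s1` — 1.1

Two compounds have been run in a functional assay for agonist activity at growth hormone secretagogue receptor type 1 (Homo sapiens), read by FLIPR; on this read-out higher numbers stand for larger maximal responses and lower numbers for smaller maximal responses. Compound 1 gives 0.9, and compound 2 gives 1.1. Of the two numbers, compound 2 stands higher. The gap between compound 2 and compound 1 lies beyond the usual scatter of this kind of measurement, so the two are distinguishable, with both reaching a large share of the reference agonist's response.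

Compound 3, `CC(=O)c1ccc(N2C[C@@H](C)N[C@@H](C)C2)cc1NS(=O)(=O)c1ccc(-c2ccccn2)s1`, has not yet been measured. It differs from compound 2 in one place: acetyl in place of methoxy on an aromatic carbon. The change sits on an aromatic carbon of a six-membered aromatic ring of carbon only, ortho to a large group and para to the 3,5-dimethylpiperazin-1-yl group.

Within the data shown here, no measured pair shows what this kind of exchange does here, so the expectation rests on the two numbers alone. Because compound 2 gives 1.1, a near-full response, the step from it to compound 3 is expected to be small, most likely none beyond the scatter, a number 0.10 lower from compound 2 to compound 3 (within the scatter). In this assay compound 3 is estimated at 1, within a range from 0.7 to 1.2.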

Compound 3, intrinsic activity: the largest response reached, as a fraction of the reference agonist's: 0.9
Beside the measured number, compound 3's estimate is 0.10 above it; measured number inside the range.
By their numbers in this assay, from the lowest: compounds 1 and 3 (each within the scatter of the next); then compound 2.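

In this assay, putting acetyl in place of methoxy on this aromatic carbon, ortho to a large group and para to a 3,5-dimethylpiperazin-1-yl group, gives a number 0.20 lower from compound 2 to compound 3 (beyond the scatter). Among these compounds, this is the first sign that the maximal response depends on the group at this position, yet the exchange does not abolish agonism: compound 3 still gives 0.9, a large share of the reference agonist's response. Nothing available on these compounds accounts for the step.

With a single exchange at this position, the compounds shown cannot separate the effect of losing methoxy from that of gaining acetyl, and they do not establish whether the step reflects a general preference at this carbon or something particular to this pair. Going by these compounds, what a hydroxyl, an amine, a carboxylic acid or a longer chain such as propanoyl would do on the same carbon remains open, as does whether the same exchange would give a similar step elsewhere.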